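Iodo in Place of Acetyl: What to Expect for Compound 4

The source may hold more compounds than are shown below. What is called first, only, known or untested is meant among the compounds shown, and "the series" means these compounds.

In an assay on isolated protein for binding affinity to corticotropin-releasing factor receptor 1 (Homo sapiens) (a higher number here means a weaker inhibitor, a lower number a stronger inhibitor), the measured compounds stand as follows: compound 1 `CCN(CC)c1cc(C)nc(N(CC)c2ccc(N(C)C)cc2Br)n1` at 27 nM; compound 2 `CCN(CC)c1cc(C)nc(N(CC)c2ccc(C(C)=O)cc2Br)n1` at 5 nM; compound 3 `CCN(CC)c1cc(C)nc(N(CC)c2ccc(C(C)C)cc2Br)n1` at 22 nM; 30 nM (2 entries).

Within the data shown here, compound 2 holds the lowest of the two single numbers, with compound 1 the nearest; the one measured step, a 5.4-fold lower number from compound 1 to compound 2 (0.73 log units; beyond the scatter), separates them. The repeated entries of compound 3 (the several entries of compound 3 in this assay, 22 nM; 30 nM (2 entries)) sit close to compound 1.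

Compound 4 `CCN(CC)c1cc(C)nc(N(CC)c2ccc(I)cc2Br)n1` differs from compound 2 by iodo in place of acetyl on an aromatic carbon. The step that bears on this is a 5.4-fold lower number from compound 1 to compound 2 (0.73 log units; beyond the scatter), where the acetyl entering brought the number down; compound 4 removes that acetyl again, so a modest rise beyond the scatter is expected, with compound 3 (the several entries of compound 3 in this assay, 22 nM; 30 nM (2 entries)) marking where a group without an acceptor has landed. For compound 4 the expected value in this assay is 15 nM, between 5 nM and 45 nM. The expected step is a 3.0-fold higher number from compound 2 to compound 4 (0.48 log units; beyond the scatter).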

Compound 4, inhibition constant: 9 nM
Beside the measured number, compound 4's estimate is 1.7-fold (0.22 log units) above it, within the range that was stated.
By their numbers in this assay, from the lowest: compounds 2 and 4 (each within the scatter of the next); then compound 1.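

In this assay, the hydrogen-bond acceptor of the acetyl group proves not to be required at this position, since exchanging acetyl for iodo gives a 1.8-fold higher number from compound 2 to compound 4 (0.26 log units; within the scatter). Iodo also stands clear of dimethylamino, with a 3.0-fold lower number from compound 1 to compound 4 (0.48 log units; beyond the scatter). Compound 4 likewise sits lower than the repeated entries of compound 3: the several entries of compound 3 in this assay, 22 nM; 30 nM (2 entries)

From the compounds shown here alone, whether other small groups at this position, such as chloro, methoxy or a nitrile, would keep the number this low remains open. So does whether iodo and acetyl would still match if the bromo group were replaced.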